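The compounds below may be only part of what the source reports. "The series", "measured", "known", "first", "only" and "open" are said of these compounds alone.

In a functional assay on MCF7 cells (Homo sapiens) for cytotoxicity, read by MTT assay and propidium iodide staining, with a stated time of 24 h (a higher number here means a weaker inhibitor, a lower number a stronger inhibitor), compound 1 (`Cc1ccc(-c2nnc(SCC(=O)c3ccccc3)o2)c(O)c1`) gives 150 nM and compound 2 (`O=C(CSc1nnc(-c2ccncc2)o1)c1ccccc1`) gives 370 nM. Compound 3 (`Cc1ccc(-c2nnc(SCC(=O)c3ccc(Br)cc3)o2)c(O)c1`) gives 2070 nM, the highest of the three numbers. The next change leads to compound 4 (`O=C(CSc1nnc(-c2ccncc2)o1)c1ccc(Br)cc1`), with pyridin-4-yl in place of 2-hydroxy-4-methylphenyl on an aromatic carbon of the five-membered aromatic ring: pyridin-4-yl in place of 2-hydroxy-4-methylphenyl on an aromatic carbon. The same exchange separates compound 1 from compound 2, without the bromo, and the higher number lies with pyridin-4-yl, at 370 nM for compound 2. Compound 4 is also the bromo counterpart of compound 2. Among the compounds with values here, the one measured bromo step is large, a 14-fold higher number from compound 1 to compound 3 (1.14 log units; beyond the scatter), and it also runs upward. Both comparisons point the same way, so a rise is expected in this assay, although each rests on a single pair. The expected step is a 2.2-fold higher number from compound 3 to compound 4 (0.34 log units; beyond the scatter). For compound 4 the estimated value is 4500 nM, with an expected range of 1300 nM to 15000 nM.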

Compound 4, half-maximal inhibitory concentration: 4230 nM
For compound 4 the middle estimate is 1.1-fold (0.03 log units) above the measured one; the range from low to high includes it.
By their numbers in this assay, from the lowest: compound 1; then compound 2; then compound 3; then compound 4.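

In this assay, pyridin-4-yl in place of 2-hydroxy-4-methylphenyl on the five-membered aromatic ring gives a 2.0-fold higher number from compound 3 to compound 4 (0.31 log units; beyond the scatter), so this position still moves the number when the bromo is present, though only modestly. Bromo in place of hydrogen, earlier seen as a single pair, now gives an 11-fold higher number from compound 2 to compound 4 (1.06 log units; beyond the scatter), a large rise on a second core. The size of the bromo step therefore carries across both cores shown: the same change on two cores in this assay, a 14-fold higher number (1.14 log units; beyond the scatter) from compound 1 to compound 3 and an 11-fold higher number (1.06 log units; beyond the scatter) from compound 2 to compound 4, 1.2-fold (0.08 log units) apart, within the scatter of two such steps.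

Open, as far as these compounds go, is whether a fluoro, a methoxy or an amine on that same aromatic carbon raises the number as bromo does. Also open is which part of the exchange at the five-membered ring carries the step, since plain phenyl, which would separate the ring nitrogen from the hydroxy and methyl groups, is absent from the compounds shown.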